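A few compounds are considered here, and "the series" means these few. Any claim that something is new, unique, unknown or untested is made for them only; others in the source may bear on it.

Measured compounds:
compound 1, `c1ccc(-c2ccc3c(NCCCNCc4ccco4)ccnc3c2)cc1`: 9.47
compound 2, `COc1cccc(CNCCCNc2ccnc3cc(-c4ccccc4)ccc23)c1O`: 9.47

In a physicochemical assay for acid dissociation, compound 1 gives 9.47 and stands level with compound 2 at the digits shown, the two values lying within the scatter of each other. Among the compounds with values here, the one measured step, no change at the digits printed from compound 1 to compound 2 (within the scatter), puts 2-hydroxy-3-methoxyphenyl in place of furan-2-yl on a saturated chain carbon bound to an amine nitrogen and leaves the reading unmoved.

Compound 3, `FC(F)(F)c1ccc(-c2ccc3c(NCCCNCc4ccco4)ccnc3c2)cc1`, is not yet measured. Against compound 1 the change is trifluoromethyl in place of hydrogen on an aromatic carbon, sitting on a six-membered aromatic ring of carbon only, para to a large group; read one bond further out, phenyl becomes 4-(trifluoromethyl)phenyl. Within the data shown here, no measured step touches that ring; the only step on record alters the group on the chain carbon at the amine and bears on this case solely in showing that a swap far from the amine left the dissociation constant flat. The expected step in this assay is therefore a number 0.07 log units lower from compound 1 to compound 3 (within the scatter), nothing beyond the scatter. Compound 3 is estimated at 9.4, within 9.05 to 9.7.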

Compound 3, acid dissociation constant: 9.47
For compound 3 the middle estimate is 0.07 log units below the measured one; the measured number falls inside the stated range.
By their numbers in this assay, from the lowest: compounds 1, 2 and 3 (each within the scatter of the next).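

The terminal phenyl of the core of compound 1 now has its first measured change: as phenyl becomes 4-(trifluoromethyl)phenyl, with trifluoromethyl in place of hydrogen on an aromatic carbon para to a large group, this assay shows no change at the digits printed from compound 1 to compound 3 (within the scatter) on this substitution. Within the data shown here, until now, the only single-place change on record was at the chain carbon bound to the amine nitrogen, where the reading was no change at the digits printed from compound 1 to compound 2 (within the scatter), so the series now holds flat readings for changes at two separate places on the scaffold, at least across these three compounds. Nothing available explains why this position leaves the reading flat.

Going by these compounds, a single substituent at this position cannot show whether the flat reading is general for the ring, and it remains open whether an amine, a carboxylic acid or a methoxy group in place of trifluoromethyl would give the same number. The effect of a longer chain between the two nitrogens is also open, as is that of a methyl group on the amine nitrogen, since every compound shown keeps the same chain and leaves that nitrogen unsubstituted by methyl.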